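This account rests on a few compounds, and the source may have more. Where it says the series, first, only, none or still open, it means among the compounds named here.

Measured in a functional assay on P388 cells (Mus musculus) for cytotoxicity; a higher number here means a weaker inhibitor, a lower number a stronger inhibitor:
- compound 1 `C=CC[C@@H]1NC(=O)[C@@H](C)NC(=O)[C@@H]2Cc3ccc(OC)c(c3)Oc3ccc(cc3)C[C@@H](C(=O)N2C)N(C)C(=O)[C@H](C)NC(=O)[C@H](Cc2ccc(OC)cc2)N(C)C1=O`: 38.9 nM
- compound 2 `COc1ccc(C[C@H]2C(=O)N[C@@H](C)C(=O)N(C)[C@H]3Cc4ccc(cc4)Oc4cc(ccc4OC)C[C@@H](C(=O)N[C@H](C)C(=O)N[C@@H](CC(=O)O)C(=O)N2C)N(C)C3=O)cc1`: 1200 nM
- compound 3 `C[C@@H]1NC(=O)[C@@H](C)NC(=O)[C@@H]2Cc3cccc(c3)Oc3ccc(cc3)C[C@@H](C(=O)N2C)N(C)C(=O)[C@H](C)NC(=O)[C@H](Cc2ccccc2)N(C)C1=O`: 525 nM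

Among these three, compound 3, at 525 nM, holds the middle place, with a higher number than compound 1 and a lower one than compound 2. The next compound to be tested, compound 4 `COc1ccc2cc1Oc1ccc(cc1)C[C@H]1C(=O)N(C)[C@@H](C2)C(=O)N[C@H](C)C(=O)N[C@@H](C)C(=O)N(C)[C@@H](Cc2ccccc2)C(=O)N[C@@H](C)C(=O)N1C`, differs from compound 3 in one place: methoxy in place of hydrogen on an aromatic carbon. In words, it has methoxy in place of hydrogen on an aromatic carbon.

Going by the values given here, no measured step shows this change directly. The only one, a 31-fold higher number from compound 1 to compound 2 (1.49 log units; beyond the scatter), is large, but it puts carboxy in place of vinyl on a saturated chain carbon, so it says little about an aromatic methoxy. Compound 1, at 38.9 nM, gives a weak hint: it carries methoxy groups that compound 3 lacks and has the lower number. However, it also differs from compound 3 elsewhere, and the data cannot separate these changes. Only a modest shift towards a stronger inhibitor therefore seems reasonable. The expected change is a 2.4-fold lower number from compound 3 to compound 4 (0.38 log units; beyond the scatter), and it remains uncertain. For compound 4 the estimated value is 220 nM, with an expected range of 70 nM to 700 nM.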

Compound 4, half-maximal inhibitory concentration: 295 nM
For compound 4 the middle estimate is 1.3-fold (0.13 log units) below the measured one; the measured number falls inside the stated range.
By their numbers in this assay, from the lowest: compound 1; then compounds 4 and 3 (each within the scatter of the next); then compound 2.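

In this assay, going by these compounds alone, the step of a 1.8-fold lower number from compound 3 to compound 4 (0.25 log units; within the scatter) is the first direct reading of this change, which the earlier compounds could only hint at. Methoxy in place of hydrogen on this aromatic carbon, part of a fused or bridged system of four rings, leaves the number within the usual scatter of repeated measurements, so no real gain or loss can be claimed for this single change. Nothing in hand offers an explanation for this outcome, so none is offered here.

From the compounds shown here alone, compound 1 still carries a second methoxy on the other aromatic ring and a longer unsaturated chain in place of a methyl group, and the effect of each of these on its own remains open. It is also unknown whether a different group at this same aromatic carbon, such as a hydroxyl, an amine or a carboxylic acid, would move the number beyond the scatter or leave it as methoxy does.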